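Cyanoaziridine ureas: an ester-to-sulfonamide swap on the aryl

A few compounds are considered here, and "the series" means these few. Any claim that something is new, unique, unknown or untested is made for them only; others in the source may bear on it.

Measured so far in a functional assay on L1210 cells (Mus musculus) for inhibition, read by MTT assay; a higher number here means a weaker inhibitor, a lower number a stronger inhibitor:
compound 1, `CCOC(=O)c1ccc(NC(=O)N2CC2C#N)cc1`, 9700 nM
compound 2, `N#CC1CN1C(=O)Nc1ccc(Cl)cc1Cl`, 207000 nM
compound 3, `N#CC1CN1C(=O)NC1CCCCC1`, 7400 nM

Compound 1 stands second highest of the three numbers. Compound 3 is the nearest to it and lies within the scatter, so the two cannot be put in order. Compound 2 is the furthest from compound 1, beyond the scatter, and carries the higher number of that pair.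

Compound 4, `N#CC1CN1C(=O)Nc1ccc(S(N)(=O)=O)cc1`, has not yet been measured in this assay. It differs from compound 1 in one place: sulfamoyl in place of ethoxycarbonyl on an aromatic carbon. Among the compounds with values here, no pair of measured compounds differs by this change, so nothing among the three measured compounds shows how a substituent swap at that aromatic carbon moves the number. The expectation in this assay is therefore a step of at most modest size, in no firm direction, possibly none beyond the scatter. Compound 4 is estimated at 12000 nM, with a range from 4000 nM to 40000 nM. The expected step from compound 1 to compound 4 is a 1.2-fold higher number from compound 1 to compound 4 (0.09 log units; within the scatter), an estimate rather than a measurement.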

Compound 4, half-maximal inhibitory concentration: > 38000 nM
Compound 4: no number, only a limit (the forecaster's own chance of this, stated with the estimate: 10%); middle value at least 3.1-fold (0.50 log units) away from the limit.
By their numbers in this assay, from the lowest: compounds 3 and 1 (each within the scatter of the next); then compound 2.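

In this assay compound 4 carries a limit of the assay and not a number: the limit of > 38000 nM in this assay, at which 1 of the 4 values shown sits. Sulfamoyl in place of ethoxycarbonyl on the aromatic carbon gives an at least 3.9-fold higher number from compound 1 to compound 4 (0.59 log units; beyond the scatter), the first step in the series that reads a change at this position, and it shows that the substituent there can move the number beyond the scatter, towards weaker inhibition. The full size of the step cannot be read, as only its lower bound is known.

The compounds shown leave open whether the loss of ethoxycarbonyl or the entry of sulfamoyl carries the step. They also leave open how a carboxylic acid, an amine or a longer ester chain on that aromatic carbon would compare with compound 1.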